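Removing the ortho-fluoro from the sulfonamide of compound 1

A few compounds are considered here, and "the series" means these few. Any claim that something is new, unique, unknown or untested is made for them only; others in the source may bear on it.

Measured compounds:
compound 1 `O=S(=O)(Nc1cc(-c2cnc3[nH]cc(-c4ccncc4)c3c2)cnc1Cl)c1ccccc1F` with 1790 nM in a functional assay on T47D cells (Homo sapiens) for inhibition, read by sulforhodamine B assay, with a stated time of 72 h; on this read-out higher numbers stand for weaker inhibition of growth and lower numbers for stronger inhibition of growth
compound 2 `O=S(=O)(Nc1cc(-c2cnc3[nH]ncc3c2)cnc1Cl)c1ccccc1` with 4400 nM
compound 3 `O=S(=O)(Nc1cc(-c2cnc3[nH]nc(-c4ccccc4)c3c2)cnc1Cl)c1ccccc1` with 4190 nM

Compound 1 gives the lowest of the three numbers in this assay; compound 3 lies a measurable gap above it and compound 2 a little further still. Within the data shown here, the step from compound 2 to compound 3 a 1.1-fold lower number from compound 2 to compound 3 (0.02 log units; within the scatter) is the only measured single change, and it does not touch the sulfonyl aryl group. Compound 4 `O=S(=O)(Nc1cc(-c2cnc3[nH]cc(-c4ccncc4)c3c2)cnc1Cl)c1ccccc1` differs from compound 1 by hydrogen in place of fluoro on an aromatic carbon. Among the measured compounds shown here, no measured step bears directly on this change, so the expected step of a 1.2-fold higher number from compound 1 to compound 4 (0.09 log units; within the scatter) is small and likely within the scatter. Compound 4 is therefore expected at about 2200 nM, within a range of 900 nM to 5500 nM.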

Compound 4, concentration for 50% growth inhibition: 1500 nM
For compound 4 the middle estimate is 1.5-fold (0.17 log units) above the measured one, and the stated range covers the measured number.
By their numbers in this assay, from the lowest: compounds 4 and 1 (each within the scatter of the next); then compounds 3 and 2 (each within the scatter of the next).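

In this assay, among these compounds, the swap of 2-fluorophenyl to phenyl gives the first direct reading at this position (a 1.2-fold lower number from compound 1 to compound 4 (0.08 log units; within the scatter)), and this step lies within the scatter. On this read-out, fluoro and hydrogen on this aromatic carbon cannot be told apart in compounds that share the pyridyl-bearing core of compound 1. Nothing at hand offers a reason for this result.

On these data alone, it remains open whether a methoxy group, an amine or a carboxylic acid on this carbon would move the number beyond the scatter.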